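Furoyl-thioimidazolidine acrylamides: amide swapped for benzoyl

The source may report more compounds than this note shows. Statements on the series, on what has been measured and on what is new or still open speak of the compounds shown alone.

Measured compounds:
compound 1, `N#C/C(=C\N1CCN(C(=O)c2ccco2)C1=S)C(=O)Nc1ccc(Cl)cc1`, 11800 nM
compound 2, `N#C/C(=C\N1CCN(C(=O)c2ccco2)C1=S)C(N)=O`, 12000 nM

In a functional assay on SN12C cells (Homo sapiens) for inhibition, read by sulforhodamine B assay, with a stated time of 48 h (a higher number here means a weaker inhibitor of growth, a lower number a stronger inhibitor of growth), compound 1 gives 11800 nM. In this assay compound 2 gives 12000 nM, which is the higher of the two numbers, though the step of a 1.0-fold higher number from compound 1 to compound 2 (0.01 log units; within the scatter) shows that the gap between compound 2 and compound 1 is within the scatter. Going by the values given here, the single step measured so far, the exchange of the 4-chlorophenyl on the amide-type nitrogen for hydrogen, therefore left the growth inhibition unchanged.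

Compound 3, `N#C/C(=C\N1CCN(C(=O)c2ccco2)C1=S)C(=O)c1ccccc1`, has not yet been measured in this assay. It differs from compound 2 by phenyl in place of amino on a carbonyl carbon, that is, the carbamoyl of compound 2 becomes a benzoyl. Among the compounds with values here, no measured step touches the carbonyl carbon itself, so the only guide is the step from compound 1 to compound 2, in which a large change at the neighbouring amide nitrogen had no effect beyond the scatter. Compound 3 is therefore expected to give a step of no change at the digits printed from compound 2 to compound 3 (within the scatter) in this assay, with no direction favoured beyond the scatter. Compound 3 is estimated at 12000 nM, in the range 4000 nM to 36000 nM.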

Compound 3, concentration for 50% growth inhibition: 8600 nM
For compound 3 the middle estimate is 1.4-fold (0.14 log units) above the measured one; low and high end bracket the measured number.
By their numbers in this assay, from the lowest: compounds 3, 1 and 2 (each within the scatter of the next).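

The carbonyl carbon itself now carries a different group: in this assay the step of a 1.4-fold lower number from compound 2 to compound 3 (0.14 log units; within the scatter) comes with phenyl in place of amino, and the step of a 1.4-fold lower number from compound 1 to compound 3 (0.14 log units; within the scatter) comes with phenyl in place of (4-chlorophenyl)amino. Earlier, only the group on the amide-type nitrogen had been varied, whereas compound 3 has no such nitrogen at all, and the number for this benzoyl compound still lies within the scatter of those for both amides. Among these three compounds, then, amino, (4-chlorophenyl)amino and phenyl on this carbonyl carbon cannot be told apart by growth inhibition, and no available evidence bears on why these numbers lie so close.

As far as these compounds go, whether a methyl group, a longer alkyl chain or a carboxylic acid in the same place would give a number beyond the scatter remains open. From the compounds shown here alone, all three compounds also keep the furoyl group and the nitrile, so what happens when either is replaced, for example the furoyl by an acetyl group, is equally open.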